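A few compounds are considered here, and "the series" means these few. Any claim that something is new, unique, unknown or untested is made for them only; others in the source may bear on it.

Of the compounds shown here, three sharing one core have been measured in an ADME assay on HEK-293T cells (Homo sapiens) for cytotoxicity, read by MTT assay, with a stated time of 24 h; on this read-out higher numbers stand for lower toxicity in this test and lower numbers for higher toxicity in this test. Compound 1 `Cc1ccc(-c2nn(-c3ccccc3)cc2-c2nc3ccccc3n2C(=O)c2ccccc2C)cc1` gives 176000 nM in this assay. Compound 2 `Cc1ccccc1C(=O)n1c(-c2cn(-c3ccccc3)nc2-c2ccc(F)cc2)nc2ccccc21` carries fluoro in place of methyl on an aromatic carbon and gives 189000 nM; the step is a 1.1-fold higher number from compound 1 to compound 2 (0.03 log units; within the scatter). Compound 3 `Cc1ccc(-c2nn(-c3ccccc3)cc2-c2nc3ccccc3n2C(=O)c2cccc(C)c2)cc1` gives 195000 nM; that step is a 1.1-fold higher number from compound 1 to compound 3 (0.04 log units; within the scatter). Compound 4 `Cc1cccc(C(=O)n2c(-c3cn(-c4ccccc4)nc3-c3ccc(F)cc3)nc3ccccc32)c1` has not yet been measured. Among the measured compounds shown here, it differs from compound 3 by fluoro in place of methyl on an aromatic carbon, the same change at the same place as the one between compound 1 and compound 2, while the two cores differ by 3-methylphenyl in place of 2-methylphenyl on a carbonyl carbon. Because the earlier step of a 1.1-fold higher number from compound 1 to compound 2 (0.03 log units; within the scatter) stayed within the scatter, a similarly small step, a 1.1-fold higher number from compound 3 to compound 4 (0.02 log units; within the scatter), is expected here. Compound 4 is therefore estimated to give 205000 nM in this assay, with a likely range from 120000 nM to 340000 nM.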

Compound 4, half-maximal cytotoxic concentration: 148000 nM
The estimate for compound 4 lay 1.4-fold (0.14 log units) above the measured number; low and high end bracket the measured number.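

Replacing 4-methylphenyl with 4-fluorophenyl gives a 1.3-fold lower number from compound 3 to compound 4 (0.12 log units; within the scatter) and this matches the step seen on the other core: the same change on two cores in this assay, a 1.1-fold higher number (0.03 log units; within the scatter) from compound 1 to compound 2 and a 1.3-fold lower number (0.12 log units; within the scatter) from compound 3 to compound 4, 1.4-fold (0.15 log units) apart, within the scatter of two such steps. Replacing 2-methylphenyl with 3-methylphenyl on the carbonyl carbon gives a 1.3-fold lower number from compound 2 to compound 4 (0.11 log units; within the scatter) and this change also carries across: the same change on two cores in this assay, a 1.1-fold higher number (0.04 log units; within the scatter) from compound 1 to compound 3 and a 1.3-fold lower number (0.11 log units; within the scatter) from compound 2 to compound 4, 1.4-fold (0.15 log units) apart, within the scatter of two such steps. Among the compounds shown here, both changes therefore behave alike on the two cores, but every step here lies within the scatter, so this shows only that neither change had a clear effect in these pairs, not that a larger effect would carry over in the same way.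

From the compounds shown here alone, it remains open what a chloro, an amine or a carboxylic acid would do in place of the fluoro. Whether any group there can move the number beyond the scatter is also unknown.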